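The compounds below may be only part of what the source reports. "The series", "measured", "known", "first", "only" and "open" are said of these compounds alone.

Four related compounds are compared here for how strongly they harm human embryonic kidney cells in an ADME assay on HEK293 cells (Homo sapiens) for cytotoxicity, with a stated time of 72 h; on this read-out higher numbers stand for an effect only at larger amounts of compound and lower numbers for an effect already at smaller amounts. Compound 1 has the structure `O=C(Nc1ccc(F)c(-c2nc3ccccc3s2)c1)c1cc([N+](=O)[O-])ccc1Cl` and compound 2 the structure `O=C(Nc1cccc(-c2nc3ccccc3s2)c1)c1cc([N+](=O)[O-])ccc1Cl`. Compound 3 has the structure `O=C(Nc1nc(-c2cccc(F)c2)cs1)c1cc([N+](=O)[O-])ccc1Cl`, and compound 4, not yet measured, has the structure `O=C(Nc1nc(-c2ccc(F)c(F)c2)cs1)c1cc([N+](=O)[O-])ccc1Cl`.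

In this assay compound 1 gives a result that is a limit of the assay, not a number, at > 25000 nM. Compound 2 likewise gives only a limit, at > 27000 nM. Going by the values given here, compound 3 gives 8700 nM, the only number among the three measured values. Compound 1 and compound 2 differ by fluoro in place of hydrogen on an aromatic carbon. The step from compound 2 to compound 1 is a step that the two limits leave unreadable from compound 2 to compound 1, since both sit at limits: the limit of > 25000 nM in this assay, at which 1 of the 3 values shown sits, and (the limit of > 27000 nM in this assay, at which 1 of the 3 values shown sits).

Compound 4 differs from compound 3 by fluoro in place of hydrogen on an aromatic carbon. Among the compounds with values here, this is the same kind of change as the one between compound 2 and compound 1, but not the same: in compound 1 the fluoro group sits ortho to a 1,3-benzothiazol-2-yl group, whereas in compound 4 it sits ortho to a fluoro group. The difference between the core of compound 3 and the core of compound 2 is not broken down here.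

For compound 4 a step from compound 3 of about a 1.0-fold higher number from compound 3 to compound 4 (0.01 log units; within the scatter) is expected, resting only on the fact that the step from compound 2 to compound 1, a step that the two limits leave unreadable from compound 2 to compound 1, gave no readable size. Compound 4 is therefore estimated at 9000 nM, between 3500 nM and 25000 nM.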

Compound 4, half-maximal effective concentration: 8300 nM
Beside the measured number, compound 4's estimate is 1.1-fold (0.04 log units) above it, within the range that was stated.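

In this assay, the change from 3-fluorophenyl to 3,4-difluorophenyl, which places the new fluoro ortho to a fluoro group, gives a 1.0-fold lower number from compound 3 to compound 4 (0.02 log units; within the scatter), so on the core of compound 3 the added fluoro leaves the read-out within the usual scatter. This does not show that the change behaves alike on another core, because the matching step on the core of compound 2 cannot be read, with compound 1 resting on a limit of the assay and not on a number: the limit of > 25000 nM in this assay, at which 1 of the 4 values shown sits. Compound 2 also rests on a limit of the assay and not on a number, so the one readable step stands alone and says nothing about carrying the change across cores: the limit of > 27000 nM in this assay, at which 1 of the 4 values shown sits.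

On these data alone, what an amine or a carboxylic acid in place of the new fluoro would do on the core of compound 3 stays open, as does whether the fluoro step on the core of compound 2 would match if both of its compounds gave numbers. All four compounds also share the nitro group and the chloro group, so the effect of a nitrile in place of that nitro group is open too.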